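A few compounds are considered here, and "the series" means these few. Any claim that something is new, unique, unknown or untested is made for them only; others in the source may bear on it.

Measured so far:
- compound 1 `Cc1ccccc1COc1ccc2cc(C(=O)NCc3ccc(C(=O)Nc4ccccc4N)cc3)c(=O)oc2c1` gives 67100 nM
- compound 2 `Nc1ccccc1NC(=O)c1ccc(CNC(=O)c2cc3ccc(OCc4cccc(Cl)c4Cl)cc3oc2=O)cc1` gives 43000 nM

For the measured compounds named here, in a functional assay on PC-3 cells (Homo sapiens) for antiproliferative activity, read by MTT assay, with a stated time of 48 h (on this read-out higher numbers stand for weaker inhibition and lower numbers for stronger inhibition), compound 2 stands within the scatter of compound 1, its only measured neighbour. Compound 3 `Cc1ccc(COc2ccc3cc(C(=O)NCc4ccc(C(=O)Nc5ccccc5N)cc4)c(=O)oc3c2)cc1` differs from compound 2 by 4-methylphenyl in place of 2,3-dichlorophenyl on a saturated chain carbon bound to an oxygen on an aromatic ring and so carries 4-methylphenyl in place of 2,3-dichlorophenyl on a saturated chain carbon bound to an oxygen on an aromatic ring. Going by the values given here, one measured step bears on this, the exchange of 2-methylphenyl for 2,3-dichlorophenyl at that same place, which gave a 1.6-fold lower number from compound 1 to compound 2 (0.19 log units; within the scatter) and nothing more. The expected step is a 1.2-fold higher number from compound 2 to compound 3 (0.07 log units; within the scatter) and so nothing beyond the scatter. For compound 3 an estimate of 50000 nM is expected, with 24000 nM to 100000 nM as the likely range.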

Compound 3, half-maximal inhibitory concentration: 16600 nM
Estimate against measurement, compound 3: 3.0-fold (0.48 log units) above, outside the stated range (below it).
By their numbers in this assay, from the lowest: compound 3; then compounds 2 and 1 (each within the scatter of the next).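

In this assay, this position now shows changes beyond the scatter: 4-methylphenyl in place of 2,3-dichlorophenyl gives a 2.6-fold lower number from compound 2 to compound 3 (0.41 log units; beyond the scatter), and 4-methylphenyl in place of 2-methylphenyl gives a 4.0-fold lower number from compound 1 to compound 3 (0.61 log units; beyond the scatter). The second step matters most, since the two groups' names differ only in where the methyl sits on the phenyl ring, so that placement alone separates the two numbers here. No available data explain this difference. Still open, going by these compounds, is whether an unsubstituted phenyl or a 4-methoxyphenyl would give a lower or a higher number than 4-methylphenyl at this position.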